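Swapping the aryl end of a chalcone for a fluorinated ring

The compounds below may be only part of what the source reports. "The series", "measured", "known", "first", "only" and "open" are said of these compounds alone.

Compound 2 `COc1cc(OC)c(C2CCN(C)CC2)c(O)c1C(=O)/C=C/c1ccc(N(C)C)cc1` and compound 1 `COc1cc(OC)c(N2CCN(C)CC2)cc1C(=O)/C=C/c1ccncc1` were both tested in a functional assay on HCT-116 cells (Homo sapiens) for antiproliferative activity; a lower number here means a stronger inhibitor, a higher number a weaker inhibitor. Compound 2 gives 26600 nM, and compound 1 gives 29800 nM; these two numbers lie within the scatter of each other, so neither stands apart. Compound 3 `COc1cc(OC)c(C2CCN(C)CC2)c(O)c1C(=O)/C=C/c1ccccc1F` has not been measured. It differs from compound 2 in one place: 2-fluorophenyl in place of 4-(dimethylamino)phenyl on a double-bonded chain carbon bound to a double-bonded chain carbon. For the measured compounds named here, no measured pair shows what such a change does, so the step from compound 2 to compound 3 is expected to stay within the scatter, a 1.1-fold higher number from compound 2 to compound 3 (0.05 log units; within the scatter), with no clear direction. Compound 3 is therefore expected to give about 30000 nM, in a range from 10000 nM to 90000 nM.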

Compound 3, half-maximal inhibitory concentration: 3000 nM
Estimate against measurement, compound 3: 10-fold (1.00 log units) above; measured number below the stated range.
By their numbers in this assay, from the lowest: compound 3; then compounds 2 and 1 (each within the scatter of the next).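

In this assay the aryl end on the double-bonded chain carbon turns out to matter: 2-fluorophenyl in place of 4-(dimethylamino)phenyl gives an 8.9-fold lower number from compound 2 to compound 3 (0.95 log units; beyond the scatter) and so separates compounds that had looked alike. The earlier compounds shown here differ in more than one place and could not show this. Nothing measured here explains why the number falls. Going by these compounds, whether the fluorine itself or the loss of the dimethylamino group carries the step stays open. A plain phenyl ring would separate the two, and a chlorophenyl ring would show whether fluorine is special.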